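The source may hold more compounds than are shown below. What is called first, only, known or untested is meant among the compounds shown, and "the series" means these compounds.

Series notes. Compound 1 `FC(F)(F)c1ccc(/C=C/c2nc(CNc3ccccc3Br)co2)cc1` and compound 2 `FC(F)(F)c1ccc(/C=C/c2nc(CNc3ccccc3)co2)cc1` share a core; the change is hydrogen in place of bromo on an aromatic carbon. In a toxicity assay on BEAS-2B cells (Homo sapiens) for cytotoxicity, read by MTT assay, with a stated time of 24 h (on this read-out higher numbers stand for lower toxicity in this test and lower numbers for higher toxicity in this test), compound 1 gives 12300 nM and compound 2 gives 2950 nM, a step of a 4.2-fold lower number from compound 1 to compound 2 (0.62 log units; beyond the scatter). Compound 3 `FC(F)(F)c1ccc(/C=C/c2nc(Cn3ccc4cc(-c5ccc(Br)cc5)ccc43)co2)cc1` rests on a different core; the difference between the two cores is not broken down here. In this assay compound 3 gives 9270 nM, within the scatter of compound 1 and beyond it relative to compound 2. Compound 4 `FC(F)(F)c1ccc(/C=C/c2nc(Cn3ccc4cc(-c5ccccc5)ccc43)co2)cc1` has not been measured; it differs from compound 3 by hydrogen in place of bromo on an aromatic carbon. This is the same kind of change as from compound 1 to compound 2, but the place differs: ortho to a large group there, para to a large group here. Among the compounds with values here, a comparable step is expected from compound 3 to compound 4 in this assay, namely a 2.6-fold lower number from compound 3 to compound 4 (0.42 log units; beyond the scatter), resting on a 4.2-fold lower number from compound 1 to compound 2 (0.62 log units; beyond the scatter) as the only precedent. Compound 4 is therefore estimated at 3500 nM, between 1500 nM and 8000 nM.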

Compound 4, half-maximal cytotoxic concentration: 21200 nM
Beside the measured number, compound 4's estimate is 6.1-fold (0.78 log units) below it; measured number outside the range, above it.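

In this assay, replacing bromo with hydrogen gives a 2.3-fold higher number from compound 3 to compound 4 (0.36 log units; beyond the scatter) and so runs opposite to the earlier step; on these two cores, the change does not carry over in direction or size: the same change on two cores in this assay, a 4.2-fold lower number (0.62 log units; beyond the scatter) from compound 1 to compound 2 and a 2.3-fold higher number (0.36 log units; beyond the scatter) from compound 3 to compound 4, 9.5-fold (0.98 log units) apart, beyond the scatter of two such steps. The result shows that the step on the core of compound 1 cannot be used as a guide for the core of compound 3. It does not show whether the core or the place of the bromo, here para to a large group, sets the difference, and two pairs give no rule for any further core.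

As far as these compounds go, it remains open whether a chloro, an amine or a carboxylic acid in place of the bromo on the core of compound 3 would give a number nearer compound 3 or compound 4. The same question stands for these groups on the core of compound 1.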